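Para-substituted aryl series: cytotoxicity on lung carcinoma cells

A few compounds are considered here, and "the series" means these few. Any claim that something is new, unique, unknown or untested is made for them only; others in the source may bear on it.

Measured compounds:
compound 1 `CCOC(=O)C12C(=O)OCC=C1COC2c1ccc(F)cc1`: > 1000000 nM
compound 2 `CCOC(=O)C12C(=O)OCC=C1COC2c1ccc(Cl)cc1`: > 1000000 nM
compound 3 `CCOC(=O)C12C(=O)OCC=C1COC2c1ccc(C(C)(C)C)cc1`: > 1000000 nM

In a functional assay on A549 cells (Homo sapiens) for cytotoxicity, read by MTT assay (on this read-out higher numbers stand for weaker inhibition and lower numbers for stronger inhibition), compound 1 gives > 1000000 nM, which is a limit of the assay and not a number. In this assay compound 2 gives > 1000000 nM, again a limit. In this assay compound 3 gives > 1000000 nM, also a limit. Among the measured compounds shown here, all three values sit at the limit of > 1000000 nM in this assay, at which 3 of the 3 values shown sit, so the series so far shows no measurable cytotoxicity and no compound can be placed above or below another.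

The steps among the measured compounds are accordingly unreadable: a step that the two limits leave unreadable from compound 1 to compound 2, a step that the two limits leave unreadable from compound 1 to compound 3 and a step that the two limits leave unreadable from compound 2 to compound 3 all run between two limits, and their size cannot be stated.

Compound 4 `CCOC(=O)C12C(=O)OCC=C1COC2c1ccc(OC)cc1` differs from compound 3 in one place: methoxy in place of tert-butyl on an aromatic carbon. For the measured compounds named here, the only steps that bear on this change are the three unreadable ones, which give no direction and no size. Given that compound 3 sits at > 1000000 nM and that every measured change at this position has left the value at the same limit, compound 4 is expected to stay there as well, with the expected step of a number no higher from compound 3 to compound 4 (the limit leaves the size open) being none that can be read. The estimate for compound 4 in this assay is therefore 1000000 nM, with a range from 300000 nM to 3000000 nM, most likely reported again only as a limit.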

Compound 4, half-maximal inhibitory concentration: 9300 nM
Beside the measured number, compound 4's estimate is 110-fold (2.03 log units) above it; measured number below the stated range.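

In this assay, among the compounds shown here, this aromatic carbon proves able to shift the read-out, which the earlier compounds could not show: methoxy in place of tert-butyl gives an at least 100-fold lower number from compound 3 to compound 4 (2.03 log units; beyond the scatter), methoxy in place of chloro gives an at least 100-fold lower number from compound 2 to compound 4 (2.03 log units; beyond the scatter), and methoxy in place of fluoro gives an at least 100-fold lower number from compound 1 to compound 4 (2.03 log units; beyond the scatter). For the compounds shown here, compound 4 is the only compound here with a true number, 9300 nM, so each of these steps is a minimum size and not an exact one. Compound 1, compound 2 and compound 3 remain impossible to rank, and the steps among them cannot be read, as all three rest on one assay limit and not on a number: the limit of > 1000000 nM in this assay, at which 3 of the 4 values shown sit.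

With a single measured number the series gives no trend, and the data do not tell whether the change depends on the oxygen attached to the ring or on the methoxy group as a whole. A hydroxy, ethoxy or dimethylamino group on this aromatic carbon would test how far the effect extends beyond methoxy.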